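This account rests on a few compounds, and the source may have more. Where it says the series, first, only, none or still open, it means among the compounds named here.

In a physicochemical assay for solubility, measured as kinetic solubility, at pH 7.4 (a lower number here means a less soluble compound, a higher number a more soluble compound), compound 3 `COc1cc(N2CCC(CC(=O)N3CCCC3)CC2)ccc1Nc1nc(NC2CCCCC2)c2nc[nH]c2n1` gives 19000 nM while compound 1 `COc1cc(N2CCC(C(=O)N3CCC(N(C)C)C3)CC2)ccc1Nc1nc(NC2CCCCC2)c2nc[nH]c2n1` gives 38000 nM and compound 2 `COc1cc(N2CCC(CC(=O)N3CCN(C)CC3)CC2)ccc1Nc1nc(NC2CCCCC2)c2nc[nH]c2n1` gives 38000 nM so the three sit within the usual scatter of one another. Compound 4 `COc1cc(N2CCC(C(=O)N3CC(O)C3)CC2)ccc1Nc1nc(NC2CCCCC2)c2nc[nH]c2n1` is still unmeasured. Its change is (3-hydroxyazetidin-1-yl)carbonyl in place of ((pyrrolidin-1-yl)carbonyl)methyl on a saturated ring carbon with (3-hydroxyazetidin-1-yl)carbonyl in place of ((pyrrolidin-1-yl)carbonyl)methyl on a saturated ring carbon. Among the compounds with values here, no measured step makes this exact swap. The nearest guides are a 2.0-fold lower number from compound 1 to compound 3 (0.30 log units; within the scatter) and a 2.0-fold lower number from compound 2 to compound 3 (0.30 log units; within the scatter) and also no change at the digits printed from compound 1 to compound 2 (within the scatter) and all of them stay within the scatter, so no step beyond it is expected in this assay here. The estimated step is a 1.5-fold higher number from compound 3 to compound 4 (0.17 log units; within the scatter) and so no real change is expected. For compound 4 the expected value is 28000 nM with an estimated range from 12000 nM to 60000 nM in this measurement.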

Compound 4, solubility: 19000 nM
Compound 4: the middle estimate sits 1.5-fold (0.17 log units) above what was measured; measured number inside the range.
By their numbers in this assay, from the lowest: compounds 3, 4, 1 and 2 (each within the scatter of the next).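

In this assay, putting (3-hydroxyazetidin-1-yl)carbonyl in place of ((pyrrolidin-1-yl)carbonyl)methyl gives no change at the digits printed from compound 3 to compound 4 (within the scatter). Set against the groups carrying a 4-methylpiperazin-1-yl or a 3-(dimethylamino)pyrrolidin-1-yl, the same group gives a 2.0-fold lower number from compound 2 to compound 4 (0.30 log units; within the scatter) and a 2.0-fold lower number from compound 1 to compound 4 (0.30 log units; within the scatter). So a group with a hydroxyl, the first hydrogen-bond donor in this part of these compounds, stays within the scatter of the other three at this position. Nothing measured here offers an explanation for this flat picture. As far as these compounds go, whether a carboxylic acid on this ring carbon would give a step beyond the scatter remains open.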